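Tetrazole for Triazole on a Thioether Linker

The source may hold more compounds than are shown below. What is called first, only, known or untested is meant among the compounds shown, and "the series" means these compounds.

Of the compounds shown here, two of one family have been measured in a functional assay on C6 cells (Rattus norvegicus) for cytotoxicity, read by MTT assay, with a stated time of 24 h, tested at 25 ug/mL; a lower number here means a stronger effect, a higher number a weaker effect of the compound at the concentration tested. Compound 1 `O=C(CSc1nnnn1-c1ccccc1)N/N=c1/scc(-c2ccc(F)cc2)n1-c1ccccc1` gives 49.3% in this assay. Compound 2 `Cn1cnnc1SCC(=O)N/N=c1/scc(-c2ccc(C#N)cc2)n1-c1ccccc1` gives 58.8% in this assay, the higher of the two numbers, but its gap to compound 1 lies within the usual scatter, so the two readings cannot be told apart. Among the measured compounds shown here, compound 1 and compound 2 differ in two places at once, so no single-change step is available.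

Compound 3 `N#Cc1ccc(-c2cs/c(=N/NC(=O)CSc3nnnn3-c3ccccc3)n2-c2ccccc2)cc1` is not yet measured. It differs from compound 2 in one place: 1-phenyl-1H-tetrazol-5-yl in place of 4-methyl-4H-1,2,4-triazol-3-yl on a sulfur. Compound 3 thus carries the same sulfur-linked ring as compound 1, while keeping the nitrile-bearing ring of compound 2. Because compound 1 gives 49.3% and compound 2 gives 58.8%, no change beyond the scatter is expected for this assay; if anything, a small move toward the number of compound 1 is anticipated. The step from compound 2 to compound 3 is expected to be a number 6.8 percentage points lower from compound 2 to compound 3 (within the scatter). Compound 3 is estimated to give 52% in this assay, within a range of 40% to 65%.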

Compound 3, a percentage reported as activity, at one concentration (the size of the read-out at that concentration, not a potency): 64.2%
Beside the measured number, compound 3's estimate is 12.2 percentage points below it; the measured number falls inside the stated range.
By their numbers in this assay, from the lowest: compounds 1, 2 and 3 (each within the scatter of the next, the first and the last beyond it).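

In this assay, 1-phenyl-1H-tetrazol-5-yl in place of 4-methyl-4H-1,2,4-triazol-3-yl on a sulfur gives a number 5.4 percentage points higher from compound 2 to compound 3 (within the scatter) and so leaves the reading indistinguishable from that of compound 2, even though the entering group brings an additional six-membered aromatic ring of carbon only. Among the compounds shown here, with that sulfur-linked ring held constant, cyano in place of fluoro on an aromatic carbon gives a number 14.9 percentage points higher from compound 1 to compound 3 (beyond the scatter) and is the only single-place step here that clears the scatter: a modest move toward a weaker effect at the concentration tested. No measured property of these groups is available to explain either step.

The compounds shown leave open whether the exchange of fluoro for cyano would give a similar step with 4-methyl-4H-1,2,4-triazol-3-yl on the sulfur, since both single-place comparisons rest on compound 3 alone. They also leave open how a methoxy group or a carboxylic acid on that same aromatic carbon would read, and a reading at one concentration cannot say how potency differs across the series.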